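Replacing a difluorocyclohexyl amide with a fluorophenyl amide

A few compounds are considered here, and "the series" means these few. Any claim that something is new, unique, unknown or untested is made for them only; others in the source may bear on it.

Compound 1, `O=C(C1CCC(F)(F)CC1)N1CC(c2nc(-c3cccc(Cl)c3)no2)C1`: 180 nM
Compound 2, `Cc1cccc(-c2noc(C3CN(C(=O)C4CCC(C(F)(F)F)CC4)C3)n2)c1`: 1000 nM
Compound 3, `Cc1ccc(S(=O)(=O)N2CC(c3nc(-c4cccc(Cl)c4)no3)C2)cc1`: > 10000 nM

Of the compounds shown here, three built on the same core have been tested in an assay on HEK293 cells for positive allosteric modulation of metabotropic glutamate receptor 5 (Homo sapiens), read by FLIPR; on this read-out lower numbers stand for an effect already at smaller amounts and higher numbers for an effect only at larger amounts of compound. Compound 1 gives 180 nM and stands lowest of the two numbers shown. Within the data shown here, compound 2 gives 1000 nM, a higher number beyond the usual scatter, though the two structures differ in more than one place and no single step can be drawn between them. For compound 3 the assay returns only a limit, > 10000 nM; this is the limit of > 10000 nM in this assay, at which 1 of the 3 values shown sits.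

Compound 4, `O=C(c1ccccc1F)N1CC(c2nc(-c3cccc(Cl)c3)no2)C1`, has not yet been measured. It differs from compound 1 in one place: 2-fluorophenyl in place of 4,4-difluorocyclohexyl on a carbonyl carbon. Among the measured compounds shown here, no measured step of this kind is available, so the expectation rests only on compound 1 and its value 180 nM. Compound 4 is expected to give 400 nM, within the range from 100 nM to 2000 nM. That estimate means a step of a 2.2-fold higher number from compound 1 to compound 4 (0.35 log units; beyond the scatter), expected to sit close to the edge of the scatter, toward a higher number.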

Compound 4, half-maximal effective concentration: > 10000 nM
Compound 4: only a limit was reported (the forecaster's own chance of this, stated with the estimate: 10%); at least 25-fold (1.39 log units) between middle value and limit.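

Among these compounds, on the carbonyl carbon, 2-fluorophenyl in place of 4,4-difluorocyclohexyl brings an at least 55-fold higher number from compound 1 to compound 4 (1.74 log units; beyond the scatter) in this assay, the only single-place step in this set, and it shows that this position is far from indifferent to the group it carries. The value of compound 4 is a limit: the limit of > 10000 nM in this assay, at which 2 of the 4 values shown sit. Neither group has hydrogen-bond donors or acceptors or a net charge, so the large step appears even though these counts stay the same and the printed change lies in the ring, aromatic against non-aromatic, and in its fluorine count.

The compounds shown do not tell whether the step comes from the aromatic ring or from the fluorine on it, or whether a plain phenyl or a pyridine ring would behave like the 2-fluorophenyl group. Nor do they show whether a plain cyclohexyl would stay close to compound 1 at 180 nM.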